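The source may hold more compounds than are shown below. What is called first, only, known or untested is meant among the compounds shown, and "the series" means these compounds.

Of the compounds shown here, three of a shared core have been measured in a functional assay on a cell-free system (plasma, Oryctolagus cuniculus) for inhibition, with stated times of 5 min, 1 min and 6 min; on this read-out lower numbers stand for stronger inhibition and higher numbers for weaker inhibition. Compound 1 `CCOC(=O)c1c(C)nc(-c2ccc(OCC(C)C)c(C#N)c2)n1O` gives 16800 nM, compound 2 `CCOC(=O)c1c(C)nc(-c2ccccc2C#N)n1OC` gives 14900 nM, and compound 3 `CCOC(=O)COn1c(-c2cccc(C#N)c2)nc(C)c1C(=O)OCC` gives 6800 nM. Compound 3 therefore carries the lowest of the three numbers in this assay, and its distance to compound 2, the nearest of the other two, as well as to compound 1, the furthest, lies beyond the usual scatter of repeated measurements, so it counts as the strongest inhibitor of the three. Among the compounds with values here, no single-point change between any two of the measured compounds is available, so no measured step can be quoted.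

Compound 4 `CCOC(=O)c1c(C)nc(-c2cccc(C#N)c2)n1OCc1ccc(Cl)cc1` has not yet been measured in this assay. It differs from compound 3 in one place: 4-chlorophenyl in place of ethoxycarbonyl on a saturated chain carbon bound to an oxygen on an aromatic ring. Because compound 3 gives 6800 nM and the other two compounds stand higher, the new compound is judged from that starting point alone. The step from compound 3 to compound 4 is expected to be a modest decrease, about a 1.7-fold lower number from compound 3 to compound 4 (0.23 log units; within the scatter), close to the edge of the usual scatter. Compound 4 is accordingly estimated to give 4000 nM in this assay, within a range from 1500 nM to 12000 nM.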

Compound 4, half-maximal inhibitory concentration: 6830 nM
Beside the measured number, compound 4's estimate is 1.7-fold (0.23 log units) below it; measured number inside the range.
By their numbers in this assay, from the lowest: compounds 3 and 4 (each within the scatter of the next); then compounds 2 and 1 (each within the scatter of the next).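

In this assay, the change from ethoxycarbonyl to 4-chlorophenyl on a saturated chain carbon bound to an oxygen on an aromatic ring gives a 1.0-fold higher number from compound 3 to compound 4 (0.00 log units; within the scatter) and so leaves the number within the scatter. Within the data shown here, this is the first single-place step available, and it shows that this position accepts two very different groups with no measurable difference in inhibition: one has no ring and carries hydrogen-bond acceptors, while the other has a six-membered aromatic ring of carbon only and no such acceptors. Nothing measured here accounts for this lack of difference.

A single step cannot show whether the position would respond in the same way to other groups on this carbon, such as an amine, a carboxylic acid, a longer alkyl chain or a phenyl ring without the chlorine. It also leaves open whether changes elsewhere on the shared core, including the ethoxycarbonyl group attached directly to the core, would move the number at all.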